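The compounds below may be only part of what the source reports. "The series", "measured", "known", "first", "only" and "open" are said of these compounds alone.

Compound 1 `COc1ccc(S(=O)(=O)c2cc3cnc(Nc4ccc5[nH]ccc5c4)nc3n(C)c2=O)cc1`: 300 nM
Compound 2 `Cn1c(=O)c(S(=O)(=O)c2ccc(F)cc2F)cc2cnc(Nc3ccc4c(c3)CC(=O)N4)nc21`: 15000 nM
Compound 3 `Cc1ccc(S(=O)(=O)c2cc3cnc(Nc4cnc5[nH]ccc5c4)nc3n(C)c2=O)cc1`: 15000 nM

All three values come from a functional assay on K562 cells (Homo sapiens) for inhibition, read by trypan blue exclusion, with a stated time of 72 h; a lower number here means a stronger inhibitor, a higher number a weaker inhibitor. Compound 2, at 15000 nM, stands level with compound 3 at the weak end of this small set, while compound 1, at 300 nM, gives a far lower number, beyond the scatter. Compound 4 `Cc1cc2cc(Nc3ncc4cc(S(=O)(=O)c5ccc(F)cc5F)c(=O)n(C)c4n3)ccc2[nH]1` departs from compound 2 in one place: a group of 10 heavy atoms (9 carbon, 1 nitrogen; one five-membered aromatic ring with 1 hetero atom, one six-membered aromatic ring of carbon only) in place of a group of 10 heavy atoms (8 carbon, 1 nitrogen, 1 oxygen; one five-membered non-aromatic ring with 1 hetero atom, one six-membered aromatic ring of carbon only), on a nitrogen on an aromatic ring. The entering group is 2-methyl-1H-indol-5-yl, on a nitrogen on an aromatic ring.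

Among the compounds with values here, no measured pair isolates this change, so the evidence is indirect. Compound 1 also has a five-membered aromatic ring with 1 hetero atom and a six-membered aromatic ring of carbon only in this place, and it gives 300 nM. Compound 3 has no such six-membered ring of carbon only and gives 15000 nM. A lower number in this assay, beyond the scatter, is therefore expected, with the estimated step of a 21-fold lower number from compound 2 to compound 4 (1.33 log units; beyond the scatter). The estimate for compound 4 is 700 nM, with an expected range from 150 nM to 5000 nM.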

Compound 4, half-maximal inhibitory concentration: 750 nM
For compound 4 the middle estimate is 1.1-fold (0.03 log units) below the measured one; measured number inside the range.
By their numbers in this assay, from the lowest: compound 1; then compound 4; then compounds 2 and 3 (each within the scatter of the next).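

In this assay, putting 2-methyl-1H-indol-5-yl on the nitrogen in place of the group with the five-membered non-aromatic ring gives a 20-fold lower number from compound 2 to compound 4 (1.30 log units; beyond the scatter). Within the data shown here, this is the first reading in which only this group changes, and it shows that the group on this nitrogen can by itself shift the number beyond the scatter. Both groups count one hydrogen-bond donor, so the step comes with a change in the five-membered ring and the loss of the carbonyl, not with a change in donor count.

Nothing measured here explains why the step is this large. As far as these compounds go, it also remains open whether the methyl of the entering group contributes to the step, and how an ethyl group or a carboxylic acid in its place would read.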